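Piperidine ether series: methoxy to acetoxy step

A few compounds are considered here, and "the series" means these few. Any claim that something is new, unique, unknown or untested is made for them only; others in the source may bear on it.

Compound 3 `COC1CCN(c2nc(C(F)(F)F)ccc2CNC(=O)C(C)c2ccc(NS(C)(=O)=O)c(F)c2)CC1` sits second highest of the three numbers shown in a functional assay on CHO-K1 cells for antagonist activity at transient receptor potential cation channel subfamily V member 1 (Homo sapiens), read by FLIPR (on this read-out higher numbers stand for weaker inhibition and lower numbers for stronger inhibition), with 2.4 nM. Compound 1 `CC(C(=O)NCc1ccc(C(F)(F)F)nc1NCc1ccc(Cl)cc1)c1ccc(NS(C)(=O)=O)c(F)c1` gives 65.7 nM, and a 27-fold lower number from compound 1 to compound 3 (1.44 log units; beyond the scatter). Compound 2 `Cc1ccc(CC2CCN(c3nc(C(F)(F)F)ccc3CNC(=O)C(C)c3ccc(NS(C)(=O)=O)c(F)c3)CC2)cc1` gives 0.2 nM, and a 12-fold higher number from compound 2 to compound 3 (1.08 log units; beyond the scatter). Compound 4 `CC(=O)OC1CCN(c2nc(C(F)(F)F)ccc2CNC(=O)C(C)c2ccc(NS(C)(=O)=O)c(F)c2)CC1` carries the change (acetyl in place of methyl on an oxygen on a saturated carbon). For the measured compounds named here, no measured step touches the oxygen substituent itself; the nearest comparison is the step from compound 2 to compound 3, which exchanged the entire group on that saturated ring carbon and was large, whereas here only the group on the oxygen changes. A step of modest size is therefore expected, direction uncertain, a 1.2-fold lower number from compound 3 to compound 4 (0.08 log units; within the scatter). Compound 4 is estimated at 2 nM, with a range from 0.5 nM to 8 nM.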

Compound 4, inhibition constant: 4 nM
Compound 4: middle estimate off by 2.0-fold (0.30 log units), on the low side, within the range that was stated.
By their numbers in this assay, from the lowest: compound 2; then compounds 3 and 4 (each within the scatter of the next); then compound 1.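

Methyl and acetyl on this oxygen read alike in this assay (a 1.7-fold higher number from compound 3 to compound 4 (0.22 log units; within the scatter)), so the extra carbonyl gives no separable result here. The acetoxy compound keeps large gaps on both sides (a 20-fold higher number from compound 2 to compound 4 (1.30 log units; beyond the scatter); a 16-fold lower number from compound 1 to compound 4 (1.22 log units; beyond the scatter)), placing it with the methoxy compound rather than with either outer compound. No available evidence bears on this result.

Open, on these data alone, is whether a longer chain on this oxygen, such as a butanoyl group, would also read like methyl and acetyl. Also open, as far as these compounds go, is how an amine or a carboxylic acid on the saturated ring carbon would compare with methoxy, acetoxy and 4-methylbenzyl.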